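A few compounds are considered here, and "the series" means these few. Any claim that something is new, unique, unknown or untested is made for them only; others in the source may bear on it.

Working notes on the series. For the measured compounds named here, compound 2 `CN(c1ccc2[nH]c(-c3n[nH]c4ccccc34)cc2n1)S(=O)(=O)c1ccc(Cl)cc1` carries the lower of the two numbers measured so far in a functional assay on SMMC-7721 cells (Homo sapiens) for antiproliferative activity, read by MTT assay, with a stated time of 72 h (on this read-out higher numbers stand for weaker inhibition and lower numbers for stronger inhibition), where compound 2 gives 12700 nM. Its nearest neighbour is compound 1 `CN(C(=O)C(C)(C)C)c1ccc2[nH]c(-c3n[nH]c4ccccc34)cc2n1`, which gives 22200 nM in this assay, and the step of a 1.7-fold lower number from compound 1 to compound 2 (0.24 log units; within the scatter) lies within the scatter, so the two cannot be ordered. Compound 3 `CN(c1ccc2[nH]c(-c3n[nH]c4ccccc34)cc2n1)S(=O)(=O)c1ccc(OC(F)(F)F)cc1` has not yet been measured. It differs from compound 2 in one place: trifluoromethoxy in place of chloro on an aromatic carbon. Going by the values given here, only one measured step exists, the one from compound 1 to compound 2, and it changes the group on a nitrogen on an aromatic ring rather than a substituent on the phenyl; it bears on compound 3 only in that the one change tried so far in this region gave no movement beyond the scatter. Among the compounds with values here, no measured step tests a substituent on the phenyl itself. The expectation for compound 3 in this assay is therefore a step of a 1.1-fold lower number from compound 2 to compound 3 (0.02 log units; within the scatter), that is, none beyond the scatter in either direction. Compound 3 is estimated at 12000 nM, with a range from 4000 nM to 36000 nM.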

Compound 3, half-maximal inhibitory concentration: 7160 nM
For compound 3 the middle estimate is 1.7-fold (0.22 log units) above the measured one; low and high end bracket the measured number.
By their numbers in this assay, from the lowest: compounds 3, 2 and 1 (each within the scatter of the next, the first and the last beyond it).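

Trifluoromethoxy in place of chloro gives a 1.8-fold lower number from compound 2 to compound 3 (0.25 log units; within the scatter) in this assay and is the first measured change on the phenyl itself. On this aromatic carbon, para to a large group, 5 heavy atoms including 1 hydrogen-bond acceptor stand in place of 1 heavy atom with no movement beyond the scatter, so compound 2 and compound 3 cannot be ordered and the position accommodates both groups in this assay. Nothing on hand bears on what lies behind this step.

With only chloro and trifluoromethoxy shown on this carbon, a single pair within the scatter defines no trend among substituents, and it remains open whether an amine, a carboxylic acid or a longer alkoxy chain would keep the number in the same range. Also open, as far as these compounds go, are whether trifluoromethoxy on another carbon of the phenyl would read the same, and whether the methyl on the sulfonamide nitrogen can give way to a longer chain with this phenyl in place.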